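A few compounds are considered here, and "the series" means these few. Any claim that something is new, unique, unknown or untested is made for them only; others in the source may bear on it.

In a functional assay on MCF7 cells (Homo sapiens) for inhibition (a higher number here means a weaker inhibitor of growth, a lower number a stronger inhibitor of growth), compound 1 (`COC(=O)c1ccsc1NC(=O)[C@@H]1CCCN1`) gives > 250 ug/mL, which is a limit of the assay and not a number. Compound 2 (`O=C(OCC(F)(F)F)c1ccsc1NC(=O)[C@@H]1CCCN1`) gives 89.7 ug/mL. Compound 3 (`COC(=O)c1ccsc1NC(=O)[C@H]1CCCN1`) differs from compound 1 thus: the two compounds have the same atoms and bonds and differ only in configuration as drawn: 1 of 1 stereo elements differ; a stereocentre at a saturated ring carbon is drawn S in compound 1 and R in compound 3, a stereocentre at a saturated ring carbon being drawn S in compound 1 and R in compound 3. Among the compounds with values here, the only measured step, an at least 2.7-fold lower number from compound 1 to compound 2 (0.44 log units; beyond the scatter), lies beyond the scatter, but it places trifluoromethyl on a saturated chain carbon and leaves the configuration unchanged. Within the data shown here, no measured step tests configuration, so no step beyond the scatter is expected, though this remains uncertain. The expected change is a step that the limit leaves unreadable from compound 1 to compound 3. Compound 3 is estimated at 280 ug/mL, with an expected range of 130 ug/mL to 500 ug/mL.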

Compound 3, concentration for 50% growth inhibition: 179 ug/mL
Compound 3: middle estimate off by 1.6-fold (0.19 log units), on the high side; measured number inside the range.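

In this assay, within the data shown here, the change from S to R at the saturated ring carbon gives an at least 1.3-fold lower number from compound 1 to compound 3 (0.14 log units; that floor lies within the scatter), the first step here that tests configuration. Any difference between these two compounds can lie only in configuration: the fact that compounds 1 and 3 differ only in the configuration as drawn. That step is only a floor, and its true size cannot be read because compound 1 stands at a limit: the limit of > 250 ug/mL in this assay, at which 1 of the 3 values shown sits.

Going by these compounds, it remains open whether the R configuration changes the number when trifluoromethyl is present, as in compound 2. On these data alone, the effect of a carboxylic acid or a longer chain in place of the ester also remains open.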